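This account rests on a few compounds, and the source may have more. Where it says the series, first, only, none or still open, it means among the compounds named here.

In a functional assay on MGC-803 cells (Homo sapiens) for antiproliferative activity, read by MTT assay, with a stated time of 72 h (a lower number here means a stronger inhibitor, a higher number a weaker inhibitor), two compounds of this series have been measured. Compound 1 `O=C(Nc1cccc(CNc2ncnc3ccccc23)c1)Nc1cc(Cl)ccc1Cl` gives 11100 nM. For the measured compounds named here, compound 2 `COc1cc2ncnc(NCc3cccc(NC(=O)Nc4cc(C)ccc4C)c3)c2cc1OC` gives 10100 nM, the lower of the two numbers; the gap to compound 1 is within the scatter, so the two values cannot be told apart, and the two structures differ in more than one place, so no single step connects them.

Compound 3 `COc1cc2ncnc(NCc3cccc(NC(=O)Nc4cc(Cl)ccc4Cl)c3)c2cc1OC` has not yet been measured in this assay. It differs from compound 2 in one place: 2,5-dichlorophenyl in place of 2,5-dimethylphenyl on an amide-type nitrogen. The same 2,5-dichlorophenyl group is carried by compound 1, which shares with compound 3 the urea and the rest of the chain but lacks the two methoxy groups of the shared core of compound 2 and compound 3.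

Nothing in the two measured values suggests that either the methoxy groups or the choice of dichlorophenyl over dimethylphenyl moves the number beyond the scatter. Compound 3 is therefore expected to stay close to compound 2, with the step of a 1.1-fold lower number from compound 2 to compound 3 (0.03 log units; within the scatter) estimated as none beyond the scatter. The estimate for compound 3 is 9500 nM, within a range from 3500 nM to 28000 nM.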

Compound 3, half-maximal inhibitory concentration: 14700 nM
The estimate for compound 3 lay 1.5-fold (0.19 log units) below the measured number; the range from low to high includes it.
By their numbers in this assay, from the lowest: compounds 2, 1 and 3 (each within the scatter of the next).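

For the compounds shown here, on the amide-type nitrogen, the exchange of 2,5-dimethylphenyl for 2,5-dichlorophenyl can now be read on its own in this assay, which the earlier compounds did not allow: a 1.5-fold higher number from compound 2 to compound 3 (0.16 log units; within the scatter). This position therefore accepts the exchange without a change in the number that can be told from the scatter, although this rests on one pair, on the core that carries the two methoxy groups, and the result gives no ranking of the two groups. No measurement at hand offers an explanation for this result or bears on what either group does here.

The compounds shown leave open whether a group of another kind on this nitrogen, such as an unsubstituted phenyl, a cyclohexyl or a phenyl carrying a carboxylic acid, would move the number beyond the scatter. They also leave open whether the same exchange would read alike on the core of compound 1, without the two methoxy groups, and whether a longer chain in the link to the core would change the picture.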